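Swapping the five-membered ring on a receptor ligand

The source may hold more compounds than are shown below. What is called first, only, known or untested is meant among the compounds shown, and "the series" means these compounds.

Compound 1 `CC(C)C(CC1C(=O)NC(=O)N1C)c1ccc(-c2ccc3cccc(F)c3c2)[nH]c1=O`: 17 nM
Compound 2 `CC(C)C(/C=C1\SC(=O)NC1=O)c1ccc(-c2ccc3cccc(F)c3c2)[nH]c1=O`: 13 nM

Both compounds share one core and differ only in the small ring hanging from the side chain. In an assay on membranes from Chem-1 cells for displacement of a labelled ligand from prostaglandin E2 receptor EP3 subtype (Homo sapiens), read by scintillation counting, with a stated time of 2 h (a higher number here means a weaker inhibitor, a lower number a stronger inhibitor), compound 2 has the lowest of the two numbers, yet a 1.3-fold lower number from compound 1 to compound 2 (0.12 log units; within the scatter), so the two are indistinguishable here. Compound 3 `CC(C)C(CC1NC(=O)NC1=O)c1ccc(-c2ccc3cccc(F)c3c2)[nH]c1=O` is the next variant: a group of 8 heavy atoms (4 carbon, 2 nitrogen, 2 oxygen; one five-membered non-aromatic ring with 2 hetero atoms) in place of a group of 8 heavy atoms (4 carbon, 1 nitrogen, 2 oxygen, 1 sulfur; one five-membered non-aromatic ring with 2 hetero atoms), on a saturated chain carbon bound to an aromatic carbon and a saturated chain carbon. Within the data shown here, the only measured step that touches this part of the molecule is the one from compound 1 to compound 2, and it stayed within the scatter, so exchanging one five-membered ring for another has so far not shifted the number. Compound 3 also carries a saturated linker like compound 1. The expectation is therefore for compound 3 a step of a 1.2-fold higher number from compound 2 to compound 3 (0.06 log units; within the scatter), nothing beyond the scatter, and an estimated value of 15 nM, ranging from 6 nM to 40 nM.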

Compound 3, inhibition constant: 10 nM
Beside the measured number, compound 3's estimate is 1.5-fold (0.18 log units) above it, within the range that was stated.
By their numbers in this assay, from the lowest: compounds 3, 2 and 1 (each within the scatter of the next).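

In this assay, putting the (2,5-dioxoimidazolidin-4-yl)methyl group on the saturated chain carbon in place of the sulfur-containing ring of compound 2 gives a 1.3-fold lower number from compound 2 to compound 3 (0.11 log units; within the scatter) and so no shift that can be told from the scatter. The new compound also isolates a smaller change, hydrogen in place of methyl on an amide-type nitrogen in a ring, and this gives a 1.7-fold lower number from compound 1 to compound 3 (0.23 log units; within the scatter) so the number stays within the scatter with or without that methyl. Nothing measured here says how either change acts on the receptor.

Going by these compounds, all three compounds keep a five-membered non-aromatic ring with 2 hetero atoms at this place, so it remains open how the number would respond to a ring-free group there, such as a carboxylic acid or an amine. On these data alone, it is equally open whether a longer chain than methyl on that ring nitrogen, such as ethyl or propyl, would still leave the number within the scatter.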